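Swapping Fluoro for Hydrogen on Compound 2

The source may report more compounds than this note shows. Statements on the series, on what has been measured and on what is new or still open speak of the compounds shown alone.

Of the compounds shown here, two have been measured so far: compound 1 (`Cc1c(Cc2ccccc2)c(=O)oc2cc(OCCOc3no[n+]([O-])c3S(=O)(=O)c3ccccc3)ccc12`) and compound 2 (`COc1cc(OCCOc2no[n+]([O-])c2S(=O)(=O)c2ccccc2)ccc1C(=O)/C=C/c1ccc(F)cc1`). In a functional assay on A2780 cells (Homo sapiens) for antiproliferative activity, read by MTT assay, with a stated time of 48 h (a higher number here means a weaker inhibitor, a lower number a stronger inhibitor), compound 1 gives 12.7 nM and compound 2 gives 14.5 nM as its reading. These two numbers lie within the usual scatter of each other, so compound 2 stands level with compound 1 on this evidence.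

Compound 3 (`COc1cc(OCCOc2no[n+]([O-])c2S(=O)(=O)c2ccccc2)ccc1C(=O)/C=C/c1ccccc1`) is still unmeasured. It is compound 2 with hydrogen in place of fluoro on an aromatic carbon, para to a large group (hydrogen in place of fluoro on an aromatic carbon). Put another way, 4-fluorophenyl becomes phenyl, and the rest of the molecule stays the same.

Going by the values given here, no measured pair of compounds differs in just one place, so the data offer no direct guide to this swap. The expectation in this assay is therefore no shift beyond the scatter, in either direction. The estimated step of a 1.2-fold higher number from compound 2 to compound 3 (0.07 log units; within the scatter) is accordingly a small one. Compound 3 is expected to read about 17 nM with an estimated range from 7 nM to 42 nM in this measurement.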

Compound 3, half-maximal inhibitory concentration: 8.7 nM
The estimate for compound 3 lay 2.0-fold (0.29 log units) above the measured number, within the range that was stated.
By their numbers in this assay, from the lowest: compounds 3, 1 and 2 (each within the scatter of the next).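

Going by these compounds alone, compound 2 and compound 3 form the first pair in this set that differs in only one place, so this is the first direct reading of a single swap. Replacing fluoro with hydrogen on an aromatic carbon, para to a large group, gives a 1.7-fold lower number from compound 2 to compound 3 (0.22 log units; within the scatter) in this assay, so on this evidence the fluoro is not required for a reading in the low range seen for these compounds, and 4-fluorophenyl and phenyl cannot be told apart at this position. No accompanying data bear on why the two compounds read alike.

The compounds shown cover only fluoro and hydrogen at this position, so it remains open whether a trifluoromethyl group, an amine or a carboxylic acid there would leave the reading within the scatter or move it clearly in either direction. Going by these compounds, it is also open whether the same swap would behave alike on a different core, such as that of compound 1, since this single pair speaks only for the core it shares.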